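Aryl ester series on SK-LU-1 cells: removing the methyl

The compounds below may be only part of what the source reports. "The series", "measured", "known", "first", "only" and "open" are said of these compounds alone.

Compound 1 `CC1=CC[C@H](C(C)C)c2cc(C)c(OC(=O)c3ccc(C)cc3)cc21` is the reference point of this series. In a functional assay on SK-LU-1 cells (Homo sapiens) for antiproliferative activity, read by sulforhodamine B assay, with a stated time of 48 h, tested at 50 uM (on this read-out higher numbers stand for more inhibition at the one concentration tested (going by the name of the read-out) and lower numbers for less inhibition), compound 1 gives 85.4%, the highest of the two numbers recorded so far. Compound 2 `Cc1cc2c(C(C)C)ccc(C)c2cc1OC(=O)c1cccc(C(F)(F)F)c1` differs from compound 1 in both the core and the ester; in this assay compound 2 gives 17.3%. The two values lie far apart, beyond the usual scatter, but no single-point comparison connects them, so only the values themselves are noted.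

Compound 3 `CC1=CC[C@H](C(C)C)c2cc(C)c(OC(=O)c3ccccc3)cc21` is not yet measured. Its difference from compound 1 is hydrogen in place of methyl on an aromatic carbon. Among the measured compounds shown here, no step between measured compounds isolates this change, so its size is not known from the series. A small loss, or none beyond the scatter, is expected for compound 3, since compound 1 gives 85.4% with the same core and ester linkage retained. Compound 3 is estimated at 75%, within 50% to 92%. The expected step is a number 10.4 percentage points lower from compound 1 to compound 3 (beyond the scatter).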

Compound 3, a percentage reported as inhibition, at one concentration (the size of the read-out at that concentration, not a potency): 37%
Beside the measured number, compound 3's estimate is 38 percentage points above it, outside the stated range (below it).
By their numbers in this assay, from the lowest: compound 2; then compound 3; then compound 1.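

In this assay, among the compounds shown here, the first single-change step reads a number 48.4 percentage points lower from compound 1 to compound 3 (beyond the scatter) and so shows that this position is not neutral: with the shared core and the ester linkage kept, going from 4-methylphenyl to phenyl costs a large part of the inhibition seen at the one concentration tested. The methyl on the aromatic carbon para to a large group therefore matters in this pair, although a single step gives only its size. Nothing at hand accounts for the size of this step.

As far as these compounds go, whether a longer chain such as ethyl, or a methoxy group, chlorine or an amine at the same place would match the methyl remains open. Compound 2 differs from compound 1 in more than one place, so it does not settle this.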